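The source may report more compounds than this note shows. Statements on the series, on what has been measured and on what is new or still open speak of the compounds shown alone.

Going by the values given here, in a functional assay on FaDu cells (Homo sapiens) for cytotoxicity, read by MTT assay, with a stated time of 72 h (a lower number here means that less compound is tolerated, a higher number that more compound is tolerated), compound 2 `COCC(C)n1cc(C(=O)C(=O)Nc2ccc(OC)nc2)c2ccccc21` gives 12 nM, the lowest number so far, while compound 1 `COC(=O)CCn1cc(C(=O)C(=O)Nc2ccc(OC)nc2)c2ccccc21` gives 168 nM. Compound 3 `COc1ccc(NC(=O)C(=O)c2cn(CC3CCCO3)c3ccccc23)cn1` keeps the shared core and differs from compound 2 only in the group on the aromatic nitrogen: (oxolan-2-yl)methyl in place of 1-(methoxymethyl)ethyl on an aromatic nitrogen. Among the compounds with values here, one measured step bears on this place, a 14-fold lower number from compound 1 to compound 2 (1.15 log units; beyond the scatter), and it is large. Within the data shown here, it shows that the number can respond strongly to a change here, but it gives no direct reading on the (oxolan-2-yl)methyl group, and no measured compound carries that ring. With a single step as a guide, a change much smaller than that one is expected, with some drift towards a higher number from the low value of compound 2 at 12 nM. The expected step is a 2.0-fold higher number from compound 2 to compound 3 (0.30 log units; within the scatter), a small one. Compound 3 is estimated at 24 nM, with an expected range of 7 nM to 80 nM.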

Compound 3, concentration lethal to 50% of the cells: 31 nM
Compound 3: the middle estimate sits 1.3-fold (0.11 log units) below what was measured; the measured number falls inside the stated range.
By their numbers in this assay, from the lowest: compound 2; then compound 3; then compound 1.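

In this assay the step of a 2.6-fold higher number from compound 2 to compound 3 (0.41 log units; beyond the scatter) is modest: on the aromatic nitrogen, (oxolan-2-yl)methyl, with its five-membered non-aromatic ring, does not return the number to the level of compound 1. The step of a 5.4-fold lower number from compound 1 to compound 3 (0.73 log units; beyond the scatter) confirms this, so the low numbers at this position are not confined to the open 1-(methoxymethyl)ethyl group, although that group still gives the lowest number among the three compounds. No evidence is available on what lies behind either step.

On these data alone, whether the ring oxygen matters remains open, as cyclopentylmethyl would test directly. Also unresolved is how this position responds to an amine, a carboxylic acid or a longer plain alkyl chain on the aromatic nitrogen.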